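Compound 4: 4-nitrophenyl in place of 3-chlorophenyl

This account rests on a few compounds, and the source may have more. Where it says the series, first, only, none or still open, it means among the compounds named here.

Compound 1 `Cc1ccccc1Cn1cc(COc2ccc3c(=O)ccoc3c2)nn1` gives 15300 nM in a functional assay on HeLa cells (Homo sapiens) for cytotoxicity, read by MTT assay, with a stated time of 48 h (a higher number here means a weaker inhibitor, a lower number a stronger inhibitor), and compound 2 `O=c1ccoc2cc(OCc3cn(Cc4cccc(F)c4)nn3)ccc12` gives 7550 nM in this assay. Compound 3 `O=c1ccoc2cc(OCc3cn(Cc4cccc(Cl)c4)nn3)ccc12` gives only a limit of this assay, > 100000 nM, not a number. Compound 3 thus sits at the limit of > 100000 nM in this assay, at which 1 of the 3 values shown sits, the weak edge of the three. Among the measured steps, a 2.0-fold lower number from compound 1 to compound 2 (0.31 log units; beyond the scatter); an at least 6.5-fold higher number from compound 1 to compound 3 (0.81 log units; beyond the scatter); an at least 13-fold higher number from compound 2 to compound 3 (1.12 log units; beyond the scatter). Compound 4 `O=c1ccoc2cc(OCc3cn(Cc4ccc([N+](=O)[O-])cc4)nn3)ccc12` differs from compound 3 by 4-nitrophenyl in place of 3-chlorophenyl on a saturated chain carbon bound to an aromatic nitrogen. For the measured compounds named here, no measured step exchanges a halogen for a nitro group, so none bears directly on this change; they show only that the aromatic substituent moves this assay over a wide span, with compound 3 at the top. Since compound 3 stands at a limit, the step expected is an at least 3.3-fold lower number from compound 3 to compound 4 (0.52 log units; beyond the scatter), downward, but a second limit is plausible. The estimate for compound 4 is 30000 nM, with a range from 8000 nM to 100000 nM.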

Compound 4, half-maximal inhibitory concentration: 25700 nM
Compound 4: the middle estimate sits 1.2-fold (0.07 log units) above what was measured; the range from low to high includes it.
By their numbers in this assay, from the lowest: compound 2; then compounds 1 and 4 (each within the scatter of the next). At a limit, above all of these: compound 3.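

In this assay, 4-nitrophenyl on a saturated chain carbon bound to an aromatic nitrogen gives a readable number where 3-chlorophenyl does not, with an at least 3.8-fold lower number from compound 3 to compound 4 (0.59 log units; beyond the scatter). Against the other two groups, the picture is mixed: a 3.4-fold higher number from compound 2 to compound 4 (0.53 log units; beyond the scatter), so 3-fluorophenyl keeps the lower number, while a 1.7-fold higher number from compound 1 to compound 4 (0.23 log units; within the scatter), so 4-nitrophenyl and 2-methylphenyl cannot be told apart. The limit therefore remains confined to compound 3 and does not extend to this larger group: the limit of > 100000 nM in this assay, at which 1 of the 4 values shown sits.

Still open, from the compounds shown here alone, is whether the nitro group itself or its place on the ring sets this reading, as the step from compound 3 to compound 4 changes both at once. Also open, going by these compounds, is how an amine or a carboxylic acid on this ring, or a longer chain at this position, would read.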